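The source may report more compounds than this note shows. Statements on the series, on what has been measured and on what is new or still open speak of the compounds shown alone.

Measured in a functional assay on K562 cells (Homo sapiens) for cytotoxicity, read by MTT assay, with a stated time of 48 h; on this read-out higher numbers stand for weaker inhibition and lower numbers for stronger inhibition:
- compound 1 `O=C(CN[C@H]1CCN(S(=O)(=O)Cc2ccccc2)C1)N1CCN(Cc2cccc(F)c2)CC1`: 13200 nM
- compound 2 `O=C(CN[C@H]1CCN(S(=O)(=O)Cc2ccccc2)C1)N1CCN(Cc2c(F)cccc2Cl)CC1`: 65800 nM
- compound 3 `COc1cccc(CN2CCN(C(=O)CN[C@H]3CCN(S(=O)(=O)Cc4ccccc4)C3)CC2)c1`: 60800 nM

Not yet measured: compound 4 `COc1ccc(CN2CCN(C(=O)CN[C@H]3CCN(S(=O)(=O)Cc4ccccc4)C3)CC2)cc1`.

Compound 1 has the lowest number of the three and so is the most potent in this assay, with both other compounds beyond the scatter from it. The step to compound 4 is 4-methoxyphenyl in place of 3-fluorophenyl on a saturated chain carbon bound to an amine nitrogen in a ring.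

Among the compounds with values here, the nearest precedent is the exchange of fluoro for methoxy on an aromatic carbon, a 4.6-fold higher number from compound 1 to compound 3 (0.66 log units; beyond the scatter). The other replacement of 3-fluorophenyl went the same way and was of similar size, a 5.0-fold higher number from compound 1 to compound 2 (0.70 log units; beyond the scatter). Those two changes end level, a 1.1-fold lower number from compound 2 to compound 3 (0.03 log units; within the scatter), within the scatter. Within the data shown here, no measured compound carries 4-methoxyphenyl, so the precedent is only partial, and the range is kept wide.

A modest step towards a higher number is therefore expected, estimated as a 3.6-fold higher number from compound 1 to compound 4 (0.56 log units; beyond the scatter). The value expected for compound 4 is 48000 nM, with an estimated range of 20000 nM to 100000 nM.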

Compound 4, half-maximal inhibitory concentration: 50900 nM
Beside the measured number, compound 4's estimate is 1.1-fold (0.03 log units) below it; the measured number falls inside the stated range.
By their numbers in this assay, from the lowest: compound 1; then compounds 4, 3 and 2 (each within the scatter of the next).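

In this assay the methoxy group can sit in either printed form at this position without a readable effect, as the exchange of 3-methoxyphenyl for 4-methoxyphenyl gives a 1.2-fold lower number from compound 3 to compound 4 (0.08 log units; within the scatter) and leaves the two compounds level. The new compound also sides with the disubstituted group rather than with 3-fluorophenyl: it gives a 1.3-fold lower number from compound 2 to compound 4 (0.11 log units; within the scatter) on one side, while a 3.9-fold higher number from compound 1 to compound 4 (0.59 log units; beyond the scatter) on the other confirms that, on the saturated chain carbon bound to an amine nitrogen in a ring, compound 1 alone stands apart from three level compounds with different aryl groups. Nothing available accounts for this separation or for the levelling of the other three.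

A 4-fluorophenyl, a plain phenyl or a 3-chlorophenyl group would show whether the lower number of compound 1 goes with fluoro itself, with its place on the ring or simply with the lack of a larger group. A longer chain in place of the benzyl link would test how far this end of the series tolerates change at all, and the rest of the core remains constant across all four compounds.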